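A few compounds are considered here, and "the series" means these few. Any claim that something is new, unique, unknown or untested is made for them only; others in the source may bear on it.

In a functional assay on NCI-H226 cells (Homo sapiens) for inhibition, read by sulforhodamine B assay, with a stated time of 48 h (on this read-out higher numbers stand for weaker inhibition of growth and lower numbers for stronger inhibition of growth), compound 1 (`Cc1cn([C@H]2C[C@H](CC3=CC(=O)C(=O)C=C3)[C@@H](CO[Si](C)(C)C(C)(C)C)O2)c(=O)[nH]c1=O`) has no result reported, so the series offers a single number to work from. That number belongs to compound 2 (`COc1ccc(C2([C@H]3C[C@H](n4cc(C)c(=O)[nH]c4=O)O[C@@H]3CO[Si](C)(C)C(C)(C)C)SCCCS2)cc1OC`), which gives 2000 nM in this assay and therefore cannot be ranked against any other compound. The compound still awaiting measurement is compound 3 (`COc1ccc(C2([C@H]3C[C@@H](n4cc(C)c(=O)[nH]c4=O)O[C@@H]3CO[Si](C)(C)C(C)(C)C)SCCCS2)cc1OC`). Its relation to compound 2 is the two compounds have the same atoms and bonds and differ only in configuration as drawn: 1 of 3 stereo elements differ; a stereocentre at a saturated ring carbon is drawn R in compound 2 and S in compound 3 and nothing else: a stereocentre at a saturated ring carbon is drawn R in compound 2 and S in compound 3. Among the measured compounds shown here, no measured step between compounds exists to show how much such a change matters here. With compound 2 at 2000 nM as the only anchor, the expectation stays close to that value, with any shift more likely towards weaker inhibition of growth. The expected change is a 1.5-fold higher number from compound 2 to compound 3 (0.18 log units; within the scatter) and is estimated to lie within the usual scatter. For compound 3 the estimated value is 3000 nM with an expected range from 1000 nM to 9000 nM in this assay once it is measured.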

Compound 3, concentration for 50% growth inhibition: 3390 nM
Beside the measured number, compound 3's estimate is 1.1-fold (0.05 log units) below it; low and high end bracket the measured number.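

With compound 3 the series gains its first measured step, and that step concerns a stereocentre at a saturated ring carbon, drawn R in compound 2 and S in compound 3: in this assay the switch gives a 1.7-fold higher number from compound 2 to compound 3 (0.23 log units; within the scatter). Compounds 2 and 3 therefore read as alike in this assay, and the switch at this stereocentre has no effect here that can be told apart from the scatter of repeated measurements. The comparison is a clean one, with no second structural change to weigh against it: the fact that compounds 2 and 3 differ only in the configuration as drawn.

The compounds shown leave open whether the other stereo elements tolerate a switch in the same way, since only this one differs in the measured pair. They also leave open whether a group of another kind on the shared core, such as an amine or a carboxylic acid, would move the value beyond the scatter, or whether the configuration at this stereocentre would count for more in its presence.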